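The source may report more compounds than this note shows. Statements on the series, on what has been measured and on what is new or still open speak of the compounds shown alone.

In a functional assay on A549 cells (Homo sapiens) for antiproliferative activity, read by MTT assay, with a stated time of 72 h, in the presence of a further agent that is not named here (on this read-out lower numbers stand for stronger inhibition and higher numbers for weaker inhibition), three compounds sharing one core have been measured. Compound 1 `Nc1nc2[nH]c(CCSCCC(=O)NCc3ccccn3)cc2c(=O)[nH]1` gives 77300 nM, compound 2 `Nc1nc2[nH]c(CCSCCC(=O)N[C@@H](CCC(=O)O)C(=O)O)cc2c(=O)[nH]1` gives 713 nM, and compound 3 `Nc1nc2[nH]c(CCSCCC(=O)NCc3ccncc3)cc2c(=O)[nH]1` gives 7870 nM. Compound 3 therefore holds the middle place of the three numbers, clearly separated from both of the others: the data show a 9.8-fold lower number from compound 1 to compound 3 (0.99 log units; beyond the scatter) and an 11-fold higher number from compound 2 to compound 3 (1.04 log units; beyond the scatter).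

The next compound, compound 4 `Nc1nc2[nH]c(CCSCCC(=O)NCc3cccnc3)cc2c(=O)[nH]1`, differs from compound 3 as follows: pyridin-3-yl in place of pyridin-4-yl on a saturated chain carbon bound to an amide-type nitrogen. In words, it has pyridin-3-yl in place of pyridin-4-yl on a saturated chain carbon bound to an amide-type nitrogen.

Within the data shown here, the closest precedent is a 9.8-fold lower number from compound 1 to compound 3 (0.99 log units; beyond the scatter), which is also an exchange of one pyridinyl group for another at this place. It shows that such an exchange alone can move the number beyond the scatter. The larger 110-fold lower number from compound 1 to compound 2 (2.04 log units; beyond the scatter) replaces the pyridinylmethyl group with 1,3-dicarboxypropyl, so it says little about this exchange. Among the measured compounds shown here, no pyridin-3-yl compound has been measured, so the direction is uncertain. A small move toward a higher number is expected, smaller than the step between compound 1 and compound 3, and it may not exceed the scatter. The expected step is a 1.8-fold higher number from compound 3 to compound 4 (0.25 log units; within the scatter). For compound 4, the estimated value is 14000 nM, with an expected range of 4000 nM to 50000 nM.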

Compound 4, half-maximal inhibitory concentration: 1070 nM
The estimate for compound 4 lay 13-fold (1.12 log units) above the measured number; the measured number lies below the stated range.
By their numbers in this assay, from the lowest: compounds 2 and 4 (each within the scatter of the next); then compound 3; then compound 1.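

With the same atoms joined differently, pyridin-3-yl in place of pyridin-4-yl on a saturated chain carbon bound to an amide-type nitrogen gives a 7.4-fold lower number from compound 3 to compound 4 (0.87 log units; beyond the scatter) and pyridin-3-yl in place of pyridin-2-yl gives a 72-fold lower number from compound 1 to compound 4 (1.86 log units; beyond the scatter) here, so all three pyridinyl compounds now stand apart beyond the scatter, with the lowest number at pyridin-3-yl, then pyridin-4-yl, then pyridin-2-yl. The earlier compounds shown here had left 1,3-dicarboxypropyl well ahead of both pyridinylmethyl groups, but the (pyridin-3-yl)methyl group closes that gap in this assay with a 1.5-fold higher number from compound 2 to compound 4 (0.18 log units; within the scatter) as the step, so the two carboxylic acid groups of compound 2 are not needed for a number in this range. Nothing available here accounts for the differences among the three pyridinyl compounds.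

From the compounds shown here alone, whether a plain phenyl group in place of pyridin-3-yl, a longer chain in place of the methyl of (pyridin-3-yl)methyl, or an amine or a carboxylic acid on the pyridin-3-yl ring would keep the number at this level remains open. Also open, going by these compounds, is whether the order of the three pyridinyl compounds would hold without the further agent present in the assay.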